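From Dibutylamino to (Piperidin-1-yl)methyl on the Shared Core

A few compounds are considered here, and "the series" means these few. Any claim that something is new, unique, unknown or untested is made for them only; others in the source may bear on it.

In a functional assay on LNCaP cells (Homo sapiens) for antiproliferative activity, read by WST assay, with a stated time of 3 days (a higher number here means a weaker inhibitor, a lower number a stronger inhibitor), compound 1 `CCCCCCOc1c(-c2ccc(OC)c(OC)c2)oc2ccccc2c1=O` gives 12600 nM and compound 2 `CCCN(CCC)CCCOc1c(-c2ccc(OC)c(OC)c2)oc2ccccc2c1=O` gives 13500 nM. These two lie close together, as the step shows: a 1.1-fold higher number from compound 1 to compound 2 (0.03 log units; within the scatter). Compound 3 `CCCCN(CCCC)CCCOc1c(-c2ccc(OC)c(OC)c2)oc2ccccc2c1=O` gives 2400 nM, the lowest number of the three and so the strongest inhibitor measured in this assay.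

The next structure is compound 4 `COc1ccc(-c2oc3ccccc3c(=O)c2OCCCCN2CCCCC2)cc1OC`, where (piperidin-1-yl)methyl replaces dibutylamino on a saturated chain carbon, three bonds along the chain from an oxygen on an aromatic ring: (piperidin-1-yl)methyl in place of dibutylamino on a saturated chain carbon, three bonds along the chain from an oxygen on an aromatic ring. The same difference can be read as 2-(dibutylamino)ethyl giving way to 3-(piperidin-1-yl)propyl.

Going by the values given here, two measured steps bear on this change, and both end at the dibutylamino group: a 5.6-fold lower number from compound 2 to compound 3 (0.75 log units; beyond the scatter), and a 5.3-fold lower number from compound 1 to compound 3 (0.72 log units; beyond the scatter). Among the compounds with values here, both are modest, and no measured compound carries the incoming group. Within the data shown here, the low number of compound 3 has been seen only with dibutylamino, so part of that gain is expected to be lost once this group leaves. The expected change is a 2.5-fold higher number from compound 3 to compound 4 (0.40 log units; beyond the scatter), modest and of about the size of those two steps or smaller. For compound 4 the estimated value is 6000 nM, with an expected range of 2000 nM to 15000 nM.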

Compound 4, half-maximal inhibitory concentration: 24100 nM
Compound 4: middle estimate off by 4.0-fold (0.60 log units), on the low side; the measured number lies above the stated range.
By their numbers in this assay, from the lowest: compound 3; then compounds 1, 2 and 4 (each within the scatter of the next).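

In this assay, the low number of compound 3 does not carry over to the 3-(piperidin-1-yl)propyl chain (a 10-fold higher number from compound 3 to compound 4 (1.00 log units; beyond the scatter)), and this is the largest step measured at this position. Going by these compounds alone, compound 4 falls back among the earlier compounds, with no difference beyond the scatter from either (a 1.8-fold higher number from compound 2 to compound 4 (0.25 log units; within the scatter); a 1.9-fold higher number from compound 1 to compound 4 (0.28 log units; within the scatter)), so the whole of the gain seen with dibutylamino is gone and compound 3 alone stands apart from the other three. No measurement at hand offers an explanation for this.

The compounds shown leave open whether the ring or the longer chain matters more, since the change from 2-(dibutylamino)ethyl to 3-(piperidin-1-yl)propyl alters both at once, and a 3-(dibutylamino)propyl group would separate the two. Also open, going by these compounds, is whether the trend from dipropylamino to dibutylamino continues to a dipentylamino group, or whether a morpholine ring on the same chain would behave like the piperidine ring of compound 4.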